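The source may report more compounds than this note shows. Statements on the series, on what has been measured and on what is new or still open speak of the compounds shown alone.

Measured compounds and their values in an assay on isolated protein for inhibition of Polyunsaturated fatty acid 5-lipoxygenase (Rattus norvegicus); on this read-out higher numbers stand for weaker inhibition and lower numbers for stronger inhibition:

Compound 1, `NC(=O)N(O)C1CCc2cccc(Oc3ccccc3)c21`: 5600 nM
Compound 2, `NC(=O)N(O)C1CCCc2c(OCc3ccccc3)cccc21`: 910 nM

Of the two measured compounds, compound 2 has the lower number, which on this read-out means the stronger inhibition. Among the measured compounds shown here, the only comparison available is with compound 1, whose number is higher by a gap that lies beyond the usual scatter of repeated measurements, so compound 2 stands as the stronger inhibitor of the pair. For the measured compounds named here, what these two compounds share is a core carrying the same hydroxyurea group; they differ in more than one place at once, so no single structural step links them.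

Compound 3, `COc1ccc(COc2cccc3c2CCCC3N(O)C(N)=O)cc1`, has not yet been measured in this assay. It differs from compound 2 in one place only: methoxy in place of hydrogen on an aromatic carbon. Going by the values given here, no pair of measured compounds shows what such an addition does here, so there is no measured step to lean on. With nothing in the data pointing either way, the expected step from compound 2 to compound 3 in this assay is a 1.2-fold lower number from compound 2 to compound 3 (0.08 log units; within the scatter), that is, no change beyond the scatter. For compound 3 the estimated value in this assay is therefore 750 nM, with a range from 250 nM to 2500 nM.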

Compound 3, half-maximal inhibitory concentration: 500 nM
For compound 3 the middle estimate is 1.5-fold (0.18 log units) above the measured one, within the range that was stated.
By their numbers in this assay, from the lowest: compounds 3 and 2 (each within the scatter of the next); then compound 1.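

In this assay, the swap of phenyl for 4-methoxyphenyl, with methoxy in place of hydrogen on the aromatic carbon para to a large group, gives a 1.8-fold lower number from compound 2 to compound 3 (0.26 log units; within the scatter), so the two compounds cannot be told apart on this read-out. Among the compounds shown here, this is the first step that changes one place only, and it shows that this position can carry methoxy without a shift in the number beyond the ordinary variation between repeated measurements. No measured information accounts for this result, so the step describes what happened at this position without explaining it.

The compounds shown leave open whether a different group at the same carbon, such as an amine, a carboxylic acid or a longer chain like butoxy, would move the number beyond the scatter, and whether methoxy on another carbon of this ring would behave as it does here. They also leave unresolved which of the several structural differences between compound 1 and compound 2 accounts for the gap between their values.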